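Microsomal stability of compound 2 and a proposed ester analogue

This account rests on a few compounds, and the source may have more. Where it says the series, first, only, none or still open, it means among the compounds named here.

Measured so far in an ADME assay on microsomes from liver (Mus musculus) for metabolic stability, read by LC-MS, with NADPH named in the record, with a stated time of 60 min, tested at 1 uM, in the absence of a further agent; on this read-out higher numbers stand for a more stable compound and lower numbers for a less stable compound:
- compound 1 `COc1ccc(-c2c(C)nc3c(N4CC[C@@H](NC(=O)C(F)(F)F)C4)cc(C)nn23)cc1OC` gives > 95%, a limit of the assay
- compound 2 `COc1ccc(-c2c(C)nc3c(N4CC[C@@H](NS(=O)(=O)c5ccccc5)C4)cc(C)nn23)cc1OC` gives > 95%, a limit of the assay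
- compound 3 `COc1ccc(-c2c(C)nc3c(N4CC[C@@H](NS(=O)(=O)c5ccc(NC(C)=O)cc5)C4)cc(C)nn23)cc1OC` gives > 95%, a limit of the assay

Every value here is a limit rather than a number. Compound 2 therefore stands where the other two stand, at the limit of > 95% in this assay, at which 3 of the 3 values shown sit, and it is not possible to rank it against compound 1 or compound 3. The step that the two limits leave unreadable from compound 1 to compound 2 has no readable size, and the same holds for the step that the two limits leave unreadable from compound 2 to compound 3; both steps run between two limits.

Compound 4 `COc1ccc(-c2c(C)nc3c(N4CC[C@@H](OC(C)=O)C4)cc(C)nn23)cc1OC` differs from compound 2 by acetoxy in place of (phenylsulfonyl)amino on a saturated ring carbon. Neither measured step touches this change, and neither gives a readable size, so the measured steps offer no direction for it beyond the observation that each measured analogue reached the limit. Compound 4 is expected to show a step of a number at least 10 percentage points lower from compound 2 to compound 4 (that floor lies within the scatter) relative to its parent in this assay. For compound 4 the estimated value in this assay is 85%, expected to lie between 60% and 97%.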

Compound 4, percent of the compound remaining: > 95%
Compound 4: no number, only a limit; the forecaster's own chance of this, stated with the estimate: 45%; middle value at least 10 percentage points from the limit.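

In this assay compound 4 gives > 95%, which is a limit of the assay. No step from compound 1 or compound 2 to compound 4 can be read, as all the compounds shown sit at one limit: the limit of > 95% in this assay, at which 4 of the 4 values shown sit.

The compounds shown leave open how the four rank against one another and whether any of these changes on the saturated ring carbon alters the percent of compound remaining.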